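The source may hold more compounds than are shown below. What is called first, only, known or untested is meant among the compounds shown, and "the series" means these compounds.

Measured compounds:
Compound 1 `CC1=C(C(=O)OC(C)(C)C)C(c2cccs2)NC(=O)N1` gives 26% in an assay on membranes from CHO cells for displacement of a labelled ligand from adenosine receptor A1 (Homo sapiens), read by scintillation counting, with a stated time of 60 min, tested at 1 uM; a higher number here means more inhibition at the concentration tested (going by the name of the read-out), a lower number less inhibition.
Compound 2 `CC1=C(C(=O)OCc2ccccc2)C(c2cccs2)NC(=O)N1` gives 45% in this assay.
Compound 3 `CC1=C(C(=O)OC(C)(C)C)C(c2ccoc2)NC(=O)N1C` gives 21% in this assay.

Compound 1 and compound 2 share a core and differ in one place: benzyl in place of tert-butyl on an oxygen next to a carbonyl group. That change made a step of a number 19 percentage points higher from compound 1 to compound 2 (beyond the scatter).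

Compound 4 `CC1=C(C(=O)OCc2ccccc2)C(c2ccoc2)NC(=O)N1C` has not yet been measured. It stands to compound 3 as compound 2 stands to compound 1: benzyl in place of tert-butyl on an oxygen next to a carbonyl group. The cores of compound 1 and compound 3 differ, and that difference is not broken down here.

Because the step of a number 19 percentage points higher from compound 1 to compound 2 (beyond the scatter) was modest but beyond the scatter, a step of similar size is expected from compound 3 to compound 4, that is a number 19 percentage points higher from compound 3 to compound 4 (beyond the scatter). Among the measured compounds shown here, with only one earlier example of this change, the expectation is uncertain. Compound 4 is therefore estimated at 40%, expected between 25% and 55%.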

Compound 4, a percentage reported as inhibition, at one concentration (the size of the read-out at that concentration, not a potency): 51%
Compound 4: middle estimate off by 11 percentage points, on the low side, and the stated range covers the measured number.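

Replacing tert-butyl with benzyl on an oxygen next to a carbonyl group gave, in this assay, a number 30 percentage points higher from compound 3 to compound 4 (beyond the scatter). Set beside the earlier case, the two steps agree: the same change on two cores in this assay, a number 19 percentage points higher (beyond the scatter) from compound 1 to compound 2 and a number 30 percentage points higher (beyond the scatter) from compound 3 to compound 4, 11 percentage points apart, within the scatter of two such steps. On these two cores the change therefore carries over at a similar size, but two cores cannot show that it would hold on any other core, and neither step explains why the number rises.

The compounds shown leave open how other groups on that oxygen, such as a longer chain or a chain ending in an amine or a carboxylic acid, would compare with benzyl. On these data alone, what the difference between the two cores does on its own also stays open.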